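The source may hold more compounds than are shown below. What is called first, only, known or untested is meant among the compounds shown, and "the series" means these compounds.

Measured so far in a functional assay on U-251 cells (Homo sapiens) for inhibition, read by sulforhodamine B assay, with a stated time of 48 h, tested at 10 uM; on this read-out higher numbers stand for more inhibition at the one concentration tested (going by the name of the read-out) and lower numbers for less inhibition:
- compound 1 `c1ccc(-c2cn3ccnc3c(-c3ccc4ncn(C5CCCCC5)c4c3)n2)cc1` gives 37.3%
- compound 2 `CC(=O)c1ccc(-c2cn3ccnc3c(-c3ccc4ncn(C5CCCCC5)c4c3)n2)cc1` gives 3.02%
- compound 3 `COc1ccccc1-c1cn2ccnc2c(-c2ccc3ncn(C4CCCCC4)c3c2)n1` gives 21%

Compound 3 stands second highest of the three: compound 1 is higher, as the step of a number 16.3 percentage points lower from compound 1 to compound 3 (beyond the scatter) shows, and compound 2 is lower, as the step of a number 18 percentage points higher from compound 2 to compound 3 (beyond the scatter) shows. Compound 4 `Fc1ccccc1-c1cn2ccnc2c(-c2ccc3ncn(C4CCCCC4)c3c2)n1` has not yet been measured. It differs from compound 3 in one place: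

fluoro in place of methoxy on an aromatic carbon

The measured step that bears most directly on this change is a number 16.3 percentage points lower from compound 1 to compound 3 (beyond the scatter): adding a methoxy group to the plain ring of compound 1 lowered the read-out by a modest amount. For the measured compounds named here, removing that methoxy group and putting fluoro in its place may undo part of that loss, but no measured compound carries a fluoro group, so the size is uncertain. The step of a number 34.3 percentage points lower from compound 1 to compound 2 (beyond the scatter) shows that acetyl in place of hydrogen on an aromatic carbon lowers the read-out by a large amount, so the identity of the group clearly matters. The expectation for compound 4 is a modest rise, a number 9 percentage points higher from compound 3 to compound 4 (within the scatter), though a change within the scatter is also possible. Compound 4 is therefore estimated at 30%, with a range from 15% to 45%.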

Compound 4, a percentage reported as inhibition, at one concentration (the size of the read-out at that concentration, not a potency): 11.4%
Beside the measured number, compound 4's estimate is 18.6 percentage points above it; measured number outside the range, below it.
By their numbers in this assay, from the lowest: compounds 2, 4 and 3 (each within the scatter of the next, the first and the last beyond it); then compound 1.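

In this assay, exchanging methoxy for fluoro on this aromatic carbon, ortho to a large group, gives a number 9.6 percentage points lower from compound 3 to compound 4 (within the scatter), so these two groups cannot be told apart here, and the step of a number 8.4 percentage points higher from compound 2 to compound 4 (within the scatter) likewise leaves 2-fluorophenyl and 4-acetylphenyl unresolved. The comparison with the unsubstituted ring is clearer, with a number 25.9 percentage points lower from compound 1 to compound 4 (beyond the scatter), so even the single heavy atom of fluoro goes with less inhibition than hydrogen, as methoxy does in compound 3. Nothing available explains this drop.

On these data alone, whether any group at this place can match the hydrogen of compound 1 remains open. A chloro group, an amine or a carboxylic acid there could test whether every replacement of that hydrogen lowers the read-out.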